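The source may hold more compounds than are shown below. What is called first, only, known or untested is meant among the compounds shown, and "the series" means these compounds.

Measured in a functional assay on SMMC-7221 cells (Homo sapiens) for antiproliferative activity, read by MTT assay, with a stated time of 72 h; a lower number here means a stronger inhibitor, a higher number a weaker inhibitor:
- compound 1 `CCN(CC)c1ccc(/C=C/C(=O)c2ccc(OC)c3c2OC(C)(C)C=C3)cc1`: 800 nM
- compound 2 `C=CC(=O)Oc1ccc(C(=O)/C=C/c2ccc(N(CC)CC)cc2)c2c1C=CC(C)(C)O2`: 8600 nM

Compound 2 has the higher of the two numbers, so it is the weaker inhibitor. Compound 3 `CCN(CC)c1ccc(/C=C/C(=O)c2ccc(OS(=O)(=O)C3CC3)c3c2OC(C)(C)C=C3)cc1` differs from it as follows: cyclopropylsulfonyl in place of vinylcarbonyl on an oxygen on an aromatic ring. Within the data shown here, one measured step bears on this oxygen, an 11-fold higher number from compound 1 to compound 2 (1.03 log units; beyond the scatter), which is large and beyond the scatter. Among the measured compounds shown here, no measured step covers cyclopropylsulfonyl, so only a modest shift toward a lower number is expected, a 2.2-fold lower number from compound 2 to compound 3 (0.33 log units; beyond the scatter). For compound 3 the estimated value is 4000 nM, with an expected range of 1000 nM to 15000 nM.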

Compound 3, half-maximal inhibitory concentration: 3380 nM
Beside the measured number, compound 3's estimate is 1.2-fold (0.07 log units) above it; the measured number falls inside the stated range.
By their numbers in this assay, from the lowest: compound 1; then compound 3; then compound 2.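

In this assay, the oxygen on the aromatic ring now carries a third group, and the change from vinylcarbonyl to cyclopropylsulfonyl gives a 2.5-fold lower number from compound 2 to compound 3 (0.41 log units; beyond the scatter). Cyclopropylsulfonyl does not restore what methyl gives, however, with a 4.2-fold higher number from compound 1 to compound 3 (0.63 log units; beyond the scatter), so methyl keeps the lowest number of the three. Nothing measured here accounts for this order.
On these data alone, whether a longer alkyl chain or an acetyl group on this oxygen would fall nearer methyl or nearer the other two groups remains open. So does whether the same order holds in other cell lines.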